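Benzoyl on the Amino Nitrogen of Compound 1

A few compounds are considered here, and "the series" means these few. Any claim that something is new, unique, unknown or untested is made for them only; others in the source may bear on it.

Compound 1 `CCN1CCN(CCCn2cnc3c(N4CCN(CC)CC4)nc(N)nc32)CC1`: 260 nM
Compound 2 `CCN1CCN(CCCn2cnc3c(N4CCN(C5CCCC5)CC4)nc(NCc4ccc(F)cc4)nc32)CC1`: 250 nM

Of the compounds shown here, two have been measured so far. In an assay on HEK293 cells for antagonist activity at Toll-like receptor 9 (Homo sapiens), read by spectrophotometry (a lower number here means a stronger inhibitor, a higher number a weaker inhibitor), compound 1 gives 260 nM, which is the higher of the two numbers. In this assay compound 2 gives 250 nM, and the two values lie within the usual scatter of each other, so neither compound can be called the stronger inhibitor. Compound 3 `CCN1CCN(CCCn2cnc3c(N4CCN(CC)CC4)nc(NC(=O)c4ccccc4)nc32)CC1` has not yet been measured. It differs from compound 1 in one place: benzoyl in place of hydrogen on a nitrogen on an aromatic ring, so that the amino group becomes a benzamido group. Among the compounds with values here, no measured pair differs in one place, so the data give no direct size for a step of this kind. The step of a 1.3-fold higher number from compound 1 to compound 3 (0.13 log units; within the scatter) is expected to be small, at most modestly toward a weaker inhibitor. Compound 3 is therefore estimated at 350 nM, within a range from 120 nM to 1200 nM.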

Compound 3, half-maximal inhibitory concentration: 340 nM
Estimate against measurement, compound 3: 1.0-fold (0.01 log units) above, within the range that was stated.
By their numbers in this assay, from the lowest: compounds 2, 1 and 3 (each within the scatter of the next).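

In this assay, within the data shown here, putting benzoyl in place of hydrogen on the nitrogen on the aromatic ring, so that amino becomes benzamido, gives a 1.3-fold higher number from compound 1 to compound 3 (0.12 log units; within the scatter), the first step here that changes only one place. This step lies within the scatter, so compound 1 and compound 3 cannot be told apart, even though the entering group adds 8 heavy atoms, a six-membered aromatic ring and a carbonyl at this position. No measurement shown bears on the reason for this result.

From the compounds shown here alone, it remains open whether a much smaller acyl group such as acetyl would also stay within the scatter of compound 1 at this nitrogen. The same question stands for a benzoyl group carrying a carboxylic acid on its ring.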